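The compounds below may be only part of what the source reports. "The series", "measured", "known", "first", "only" and "open" are said of these compounds alone.

Compound 1 `O=C(Nc1ccc(Cl)c(-c2nnc3c(Cl)cccn23)c1)c1ccc(F)cc1Cl`: in a functional assay on MDA-MB-468 cells (Homo sapiens) for antiproliferative activity, read by MTT assay, with a stated time of 72 h (a higher number here means a weaker inhibitor, a lower number a stronger inhibitor), compound 1 gives > 100000 nM, a limit of the assay.
Compound 2 `O=C(Nc1ccc(Cl)c(-c2nnc3c(Cl)cccn23)c1)c1ccccn1`: in this assay compound 2 gives > 100000 nM, a limit of the assay.
Compound 3 `CS(=O)(=O)c1ccc(C(=O)Nc2ccc(Cl)c(-c3nnc4c(Cl)cccn34)c2)cc1`: in this assay compound 3 gives > 100000 nM, a limit of the assay.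

Compound 2 therefore stands at the limit of this assay, with no number of its own, and the two other values shown are limits as well (the limit of > 100000 nM in this assay, at which 3 of the 3 values shown sit). The step from compound 1 to compound 2 a step that the two limits leave unreadable from compound 1 to compound 2, the step from compound 1 to compound 3 a step that the two limits leave unreadable from compound 1 to compound 3 and the step from compound 2 to compound 3 a step that the two limits leave unreadable from compound 2 to compound 3 are each left unreadable by the limits on both sides. Compound 4 `O=C(Nc1ccc(Cl)c(-c2nnc3c(Cl)cccn23)c1)c1ccccc1` is not yet measured. The change from compound 2 to compound 4 is phenyl in place of pyridin-2-yl on a carbonyl carbon. Within the data shown here, none of the measured steps bears readably on this exchange on the carbonyl carbon, since every value shown is a limit. The expectation for compound 4 is therefore no step beyond the scatter, and the step from compound 2 to compound 4 is estimated as a number no higher from compound 2 to compound 4 (the limit leaves the size open). Compound 4 is expected to give 100000 nM in this assay, within 30000 nM to 300000 nM, most likely again as a limit.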

Compound 4, half-maximal inhibitory concentration: > 100000 nM
Compound 4 was reported as a limit (the forecaster's own chance of this, stated with the estimate: 85%); the middle value lies on the limit itself.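

Compound 4 gives > 100000 nM in this assay as a limit of the assay, so its steps to compound 1, compound 2 and compound 3 cannot be read: the limit of > 100000 nM in this assay, at which 4 of the 4 values shown sit.

In this assay the compounds shown leave open how phenyl, pyridin-2-yl, 2-chloro-4-fluorophenyl and 4-(methylsulfonyl)phenyl on the carbonyl carbon compare with one another.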